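The compounds below may be only part of what the source reports. "The series", "measured", "known", "first", "only" and "open" are said of these compounds alone.

Measured compounds:
compound 1 `O=S1(=O)N=C(OCc2ccccc2)c2ccccc2N1Cc1ccc(Cl)c(Cl)c1` — > 200000 nM
compound 2 `O=C(OCOCN1c2ccccc2C(=O)N(Cc2ccccc2)S1(=O)=O)c1ccccc1` — 37000 nM

The account concerns two compounds tested in a functional assay on HEL cells (Homo sapiens) for inhibition (on this read-out lower numbers stand for higher toxicity in this test and higher numbers for lower toxicity in this test), and a third not yet tested. For compound 1 the result is not a number but a limit, > 200000 nM. Among the measured compounds shown here, compound 2, with the structure `O=C(OCOCN1c2ccccc2C(=O)N(Cc2ccccc2)S1(=O)=O)c1ccccc1`, is the one compound of the pair for which this assay returns an actual number, 37000 nM, while the other value of the set sits at the limit of > 200000 nM in this assay, at which 1 of the 2 values shown sits. Compound 2 therefore stands as the sole fixed point on the numerical scale here, and nothing further can be said about an order between the two.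

Compound 3, `C#CCOCN1c2ccccc2C(=O)N(Cc2ccccc2)S1(=O)=O`, is the untested member. It differs from compound 2 by ethynyl in place of benzoyloxy on a saturated chain carbon bound to an oxygen on a saturated carbon. For the measured compounds named here, no measured pair of this kind exists in the set, so the size of the step has to be guessed. He expects a step of a 1.6-fold higher number from compound 2 to compound 3 (0.21 log units; within the scatter), toward somewhat lower toxicity, but not clearly beyond the usual scatter. His estimate for compound 3 in this assay is 60000 nM, with a range from 15000 nM to 200000 nM.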

Compound 3, half-maximal cytotoxic concentration: > 140000 nM
Compound 3 ended at the assay's limit; the forecaster's own chance of this, stated with the estimate: 30%; middle value at least 2.3-fold (0.36 log units) away from the limit.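

Among the compounds shown here, the change of benzoyloxy to ethynyl, on a saturated chain carbon bound to an oxygen on a saturated carbon, gives the only step that can be read in this assay: an at least 3.7-fold higher number from compound 2 to compound 3 (0.57 log units; beyond the scatter). This shows that the read-out responds to what sits at this place, with the shared core left unchanged, and that lower toxicity in this test goes with ethynyl in this one pair. For compound 3 the read-out is a limit and not a number: the limit of > 140000 nM in this assay, at which 1 of the 3 values shown sits.

On these data alone, the true size of the step therefore stays unknown, and a single pair cannot tell whether the toxicity of compound 2 goes with the whole benzoyloxy group or only with a part of it, such as its aromatic ring or its carbonyl. As far as these compounds go, it also stays open how the read-out would respond at this place to a simple hydroxyl, a methoxy, an amine or a longer chain ending in a carboxylic acid, and whether the same change would give a similar step on the core of compound 1.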